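This account rests on a few compounds, and the source may have more. Where it says the series, first, only, none or still open, it means among the compounds named here.

Working notes on the series. Three compounds carry numbers in a functional assay on NCI-H460 cells (Homo sapiens) for antiproliferative activity, read by MTT assay, with a stated time of 48 h; a lower number here means a stronger inhibitor, a higher number a weaker inhibitor. Among the compounds with values here, compound 1 `O=C(CSc1nnc(NC(=O)CCl)s1)Nc1ccc(Br)cn1` gives 7500 nM, and compound 2 `O=C(CSc1nnc(NC(=O)C(Cl)Cl)s1)Nc1ccc(Br)cn1` gives 5300 nM; the one measured step is a 1.4-fold lower number from compound 1 to compound 2 (0.15 log units; within the scatter). Compound 3 `O=C(CCl)Nc1ccc(SCC(=O)Nc2ccc(Br)cn2)cc1` gives 530 nM in this assay, the lowest of the three numbers, with compound 2 nearest and compound 1 furthest, both gaps beyond the scatter. Compound 4 `O=C(CCl)Nc1ccc(SCC(=O)Nc2ccc(Cl)cc2)cc1` has not yet been measured in this assay. It differs from compound 3 in one place: 4-chlorophenyl in place of 5-bromopyridin-2-yl on an amide-type nitrogen. Within the data shown here, no measured step bears on this change: the step from compound 1 to compound 2 alters a substituent on a saturated chain carbon, not the group on the amide-type nitrogen, and compounds 1 and 2 differ from compound 3 in the shared core, a pair for which no single step is given. With nothing in the series to lean on, the expected step for compound 4 is none beyond the scatter, a 1.5-fold higher number from compound 3 to compound 4 (0.18 log units; within the scatter). Compound 4 is therefore estimated at 800 nM, within 250 nM to 2500 nM.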

Compound 4, half-maximal inhibitory concentration: 23100 nM
Compound 4: middle estimate off by 29-fold (1.46 log units), on the low side; measured number above the stated range.
By their numbers in this assay, from the lowest: compound 3; then compounds 2 and 1 (each within the scatter of the next); then compound 4.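

In this assay, the group on the amide-type nitrogen proves far from interchangeable: 4-chlorophenyl in place of 5-bromopyridin-2-yl gives a 44-fold higher number from compound 3 to compound 4 (1.64 log units; beyond the scatter), although the two groups match in heavy-atom count and each is a six-membered aromatic ring. The change replaces the ring nitrogen with carbon and the bromine with chlorine in a single step, and the hydrogen-bond acceptor count of the group falls from 1 to 0, so this step alone cannot assign the loss to any one of these differences. Nothing available on the series explains the size of the step.

The compounds shown leave open whether the ring nitrogen or the halogen carries the difference, a question that 4-bromophenyl or 5-chloropyridin-2-yl on the same nitrogen would separate. They also leave open whether the step would have the same size on the core of compound 1.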